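The compounds below may be only part of what the source reports. "The series", "measured", "known", "first", "only" and "open" are said of these compounds alone.

Of the compounds shown here, three sharing one core have been measured in an assay on cells for displacement of a labelled ligand from corticotropin-releasing factor receptor 1 (Homo sapiens), with a stated time of 100 min; a higher number here means a weaker inhibitor, a lower number a stronger inhibitor. Compound 1 `CCCN(CC1CC1)C(=O)c1c(C)nc2n(-c3c(C)cc(C)cc3C)c(Cl)cn12` gives 61 nM. Compound 2 `CCCCN(CC)Cc1c(C(F)(F)F)nc2n(-c3c(C)cc(C)cc3C)c(Cl)cn12` gives 78 nM, and compound 3 `Cc1cc(C)c(-n2c(Cl)cn3c(CN(CCC4CC4)CCC(F)(F)F)c(C(F)(F)F)nc23)c(C)c1` gives 110 nM. Among these three numbers compound 2 stands second highest; its distance to compound 1 and its distance to compound 3 both lie within the usual scatter of repeated measurements, so the three cannot be told apart with any confidence.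

The next compound, compound 4 `CCN(Cc1ccccc1)Cc1c(C(F)(F)F)nc2n(-c3c(C)cc(C)cc3C)c(Cl)cn12`, has not yet been measured. It differs from compound 2 in one place: phenyl in place of propyl on a saturated chain carbon bound to an amine nitrogen. Seen one bond further out, the change reads butyl(ethyl)amino to benzyl(ethyl)amino. Among the compounds with values here, no pair among the measured compounds isolates this particular change, so there is no measured step to lean on. What the data do show is that compounds 1, 2 and 3 carry different groups on their nitrogen and nonetheless give numbers within the scatter of one another.

The expectation for compound 4 in this assay is therefore a step of a 1.1-fold lower number from compound 2 to compound 4 (0.05 log units; within the scatter), small enough that it need not clearly exceed the scatter. Compound 4 is estimated at 70 nM, with a range from 25 nM to 200 nM.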

Compound 4, inhibition constant: 350 nM
Beside the measured number, compound 4's estimate is 5.0-fold (0.70 log units) below it, and the stated range ends below it.
By their numbers in this assay, from the lowest: compounds 1, 2 and 3 (each within the scatter of the next); then compound 4.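

In this assay, phenyl in place of propyl on a saturated chain carbon bound to an amine nitrogen gives a 4.5-fold higher number from compound 2 to compound 4 (0.65 log units; beyond the scatter), which turns butyl(ethyl)amino into benzyl(ethyl)amino and moves the number beyond the usual scatter. Within the data shown here, no earlier pair isolated a single change at this part of the molecule, so this is the first direct sign that the group on the amine nitrogen cannot be varied freely without a cost in this binding measurement. No supporting evidence is available to explain why this exchange gives a weaker inhibitor.

The compounds shown leave open whether the step follows from the aromatic ring itself or simply from replacing an open chain with a ring, and a cyclohexyl group in place of the phenyl would separate those two readings. They also leave open whether the same part of the molecule would respond differently to a pyridine ring in place of the phenyl, or to a longer link such as phenethyl in place of benzyl.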